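The source may report more compounds than this note shows. Statements on the series, on what has been measured and on what is new or still open speak of the compounds shown alone.

Working notes on the series. In an assay on MDA-MB-231 cells for displacement of a labelled ligand from C-X-C chemokine receptor type 4 (Homo sapiens) (on this read-out higher numbers stand for an effect only at larger amounts of compound and lower numbers for an effect already at smaller amounts), compound 1 `c1ccc(NCc2ccc(CNc3ncccn3)cc2)cc1` gives 10 nM. Compound 2 `c1ccc(NCc2ccc(CNc3ncccn3)cc2)nc1`, which carries pyridin-2-yl in place of phenyl on an amine nitrogen, gives 100 nM in this assay; the step is a 10-fold higher number from compound 1 to compound 2 (1.00 log units; beyond the scatter). Among the compounds with values here, on the two numbers measured so far compound 2 therefore stands highest, with compound 1 as its only neighbour, a step beyond the scatter away.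

Compound 3 `Fc1ccc(NCc2ccc(CNc3ncccn3)cc2)nc1` is the next member. Relative to compound 2 the change is fluoro in place of hydrogen on an aromatic carbon; read one bond further out, pyridin-2-yl becomes 5-fluoropyridin-2-yl.

Within the data shown here, the only measured step, from compound 1 to compound 2, exchanges the whole aryl group on the amine nitrogen and says nothing about adding fluoro to an aromatic carbon of that ring. Among the measured compounds shown here, no measured step bears on the present change, so no direction can be taken from the data, and the expected step in this assay is none beyond the scatter: no change at the digits printed from compound 2 to compound 3 (within the scatter).

For compound 3 the estimate in this assay is 100 nM, within a range from 35 nM to 300 nM.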

Compound 3, effective concentration (reported as EC, without a stated level of effect): 1 nM
Estimate against measurement, compound 3: 100-fold (2.00 log units) above; the measured number lies below the stated range.
By their numbers in this assay, from the lowest: compound 3; then compound 1; then compound 2.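

In this assay, one fluoro on an aromatic carbon two atoms from the ring nitrogen, para to a large group, gives a 100-fold lower number from compound 2 to compound 3 (2.00 log units; beyond the scatter); this large step runs against the direction of the modest one seen on exchanging the whole aryl group, a 10-fold higher number from compound 1 to compound 2 (1.00 log units; beyond the scatter). Phenyl to 5-fluoropyridin-2-yl on the amine nitrogen gives a 10-fold lower number from compound 1 to compound 3 (1.00 log units; beyond the scatter), so among these three compounds the ring nitrogen goes with a higher number than phenyl only while this position carries hydrogen. Nothing available accounts for the size of the fluoro step or for its direction.

The compounds shown leave open whether the step is specific to fluoro or would also follow from chloro, methyl or methoxy at the same carbon, and whether fluoro at another carbon of the pyridine ring would do the same. They also leave open whether fluoro on the phenyl ring of compound 1 would bring a comparable step or whether the step depends on the ring nitrogen.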